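The source may report more compounds than this note shows. Statements on the series, on what has been measured and on what is new or still open speak of the compounds shown alone.

In a functional assay on KB cells (Homo sapiens) for inhibition (on this read-out higher numbers stand for weaker inhibition and lower numbers for stronger inhibition), compound 1 `COCCOCn1cc(C#N)c2c(N)ncnc21` gives > 100000 nM, which is a limit and not a number. Compound 3 `CCOCn1cc(C#N)c2c(N)ncnc21` gives > 100000 nM, also a limit. Compound 2 `COCCOCn1cc(C(N)=S)c2c(N)ncnc21` alone has a real number, 183000 nM. Neither measured step has a readable size: one is a step that the limit leaves unreadable from compound 1 to compound 2, the other step that the two limits leave unreadable from compound 1 to compound 3. Neither touches the carbon that changes in compound 4 `COCCOCn1c(N)c(C#N)c2c(N)ncnc21`, which differs from compound 1 by amino in place of hydrogen on an aromatic carbon. With only the number of compound 2 at 183000 nM as a guide, very weak inhibition is expected to persist, with no firm direction: a step that the limit leaves unreadable from compound 1 to compound 4. The estimate for compound 4 is 150000 nM, within an expected range of 50000 nM to 400000 nM.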

Compound 4, half-maximal inhibitory concentration: 210000 nM
Compound 4: the middle estimate sits 1.4-fold (0.15 log units) below what was measured, and the stated range covers the measured number.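

No size can be read for the change from compound 1 to compound 4, because compound 1 has only a limit and not a number: the limit of > 100000 nM in this assay, at which 2 of the 4 values shown sit. On these data alone, whether amino in place of hydrogen on that aromatic carbon strengthens or weakens inhibition stays open.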